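Para substituent swap on the aryl ring: nitro for cyano

The source may report more compounds than this note shows. Statements on the series, on what has been measured and on what is new or still open speak of the compounds shown alone.

Among the measured compounds shown here, compound 2 `Cn1nnnc1SCC(=O)N/N=c1/scc(-c2ccc(C#N)cc2)n1-c1ccccc1` is the lowest of the two numbers so far in a functional assay on C6 cells (Rattus norvegicus) for cytotoxicity, read by MTT assay, with a stated time of 24 h, tested at 100 ug/mL; on this read-out higher numbers stand for a weaker effect at the one concentration tested and lower numbers for a stronger effect; compound 2 gives 30.9%, while compound 1 `Cc1ccc(-c2cs/c(=N/NC(=O)CSc3nnnn3C)n2-c2ccccc2)cc1` gives 39.7%, a gap within the scatter. For the measured compounds named here, the one measured step, a number 8.8 percentage points lower from compound 1 to compound 2 (within the scatter), also changed the substituent on the aromatic carbon para to a large group and stayed within the scatter. Compound 3 `Cn1nnnc1SCC(=O)N/N=c1/scc(-c2ccc([N+](=O)[O-])cc2)n1-c1ccccc1` carries nitro in place of cyano on an aromatic carbon. Going by the values given here, no measured step bears directly on this swap, so no step beyond the scatter is expected in this assay. Compound 3 is estimated at 31%, range 18% to 45%, meaning an expected step of a number 0.1 percentage points higher from compound 2 to compound 3 (within the scatter).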

Compound 3, a percentage reported as activity, at one concentration (the size of the read-out at that concentration, not a potency): 64.1%
Estimate against measurement, compound 3: 33.1 percentage points below; the measured number lies above the stated range.
By their numbers in this assay, from the lowest: compounds 2 and 1 (each within the scatter of the next); then compound 3.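

In this assay the aromatic carbon para to a large group proves sensitive to the substituent: the 4-cyanophenyl to 4-nitrophenyl change gives a clear weakening (a number 33.2 percentage points higher from compound 2 to compound 3 (beyond the scatter)), and the same holds against methyl (a number 24.4 percentage points higher from compound 1 to compound 3 (beyond the scatter)). Nitro therefore separates from the cyano and methyl compounds, which remain within the scatter of each other. Nothing measured on these compounds bears on the reason for this step.

Going by these compounds, whether an amine or a carboxylic acid on this carbon would read like nitro or like cyano and methyl stays open. With a single concentration per compound, these read-outs speak only of a stronger or weaker effect at that concentration.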